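The source may report more compounds than this note shows. Statements on the series, on what has been measured and on what is new or still open speak of the compounds shown alone.

In an ADME assay on RAW264.7 cells (Mus musculus) for cytotoxicity, read by MTT assay, with a stated time of 24 h (on this read-out lower numbers stand for higher toxicity in this test and higher numbers for lower toxicity in this test), the three measured compounds are:

compound 1, `CC/C=C\C[C@H]1C(=O)C=C[C@H]1CC(=O)OCC`, gives 146 uM
compound 2, `CC/C=C\C[C@H]1C(=O)C=C[C@H]1CC(=O)OCc1ccccc1`, gives 31 uM
compound 3, `CC/C=C\C[C@H]1C(=O)C=C[C@H]1CC(=O)Oc1ccccc1OC`, gives 161 uM

Compound 2 stands lowest of the three numbers, meaning it is the most toxic on this read-out: compound 1 gives a higher number, and compound 3 gives a higher number still. Among the measured compounds shown here, only one step links two of these by a single change, the step of a 4.7-fold lower number from compound 1 to compound 2 (0.67 log units; beyond the scatter), which shows that swapping the group on the oxygen next to the carbonyl moves the number beyond the scatter. Compound 3 differs from compound 2 in more than one place, so its value is noted but not traced to one change.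

Compound 4, `CC/C=C\C[C@H]1C(=O)C=C[C@H]1CC(=O)OC1CCCCC1`, follows from compound 2 by the change (cyclohexyl in place of benzyl on an oxygen next to a carbonyl group). For the measured compounds named here, no measured step shows a non-aromatic ring at this position, so the expectation rests on the one step from compound 1 to compound 2, which suggests the group here matters, and on the range spanned by the three values. For compound 4 the step of a 2.3-fold higher number from compound 2 to compound 4 (0.35 log units; beyond the scatter) is expected, a partial return toward the higher numbers of compound 1 and compound 3, with wide uncertainty. Compound 4 is estimated at 70 uM, within a range from 25 uM to 200 uM.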

Compound 4, half-maximal toxic concentration: 31 uM
For compound 4 the middle estimate is 2.3-fold (0.35 log units) above the measured one, and the stated range covers the measured number.
By their numbers in this assay, from the lowest: compounds 2 and 4 (each within the scatter of the next); then compounds 1 and 3 (each within the scatter of the next).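

In this assay, the aromatic ring of benzyl gives way to the non-aromatic ring of cyclohexyl with no change at the digits printed from compound 2 to compound 4 (within the scatter), so aromaticity at this position makes no visible difference to the toxicity number when these two groups are compared. Replacing ethyl with cyclohexyl gives a 4.7-fold lower number from compound 1 to compound 4 (0.67 log units; beyond the scatter), which closely matches a 4.7-fold lower number from compound 1 to compound 2 (0.67 log units; beyond the scatter), so the drop seen earlier does not depend on an aromatic ring. Among compounds 1, 2 and 4, then, the two six-membered-ring groups go with the lower number, but compound 3, which also has a ring on this oxygen, goes against any simple rule about rings, with a value of 161 uM.

No supporting evidence is available to explain this shared result. From the compounds shown here alone, it remains open whether the ring itself or only the size of the group sets the number, and what a straight hexyl chain or a chain ending in an amine would give on this oxygen.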